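Chloro in Place of Bromo on the Fused Aromatic Ring

A few compounds are considered here, and "the series" means these few. Any claim that something is new, unique, unknown or untested is made for them only; others in the source may bear on it.

Of the compounds shown here, three built on a shared core have been measured in a functional assay on cells (Cancer cell lines, Homo sapiens) for cytotoxicity, read by sulforhodamine B assay, with a stated time of 48 h; a lower number here means a stronger inhibitor of growth, a higher number a weaker inhibitor of growth. Compound 1 `O=C1N=C(N2N=C(c3ccccc3)CC2c2ccccc2O)S/C1=C1/C(=O)Nc2ccc(Br)cc21` gives 630 nM. Compound 2 `CN(C)c1ccc(C2CC(c3ccccc3)=NN2C2=NC(=O)/C(=C3\C(=O)Nc4ccccc43)S2)cc1` gives 18800 nM. Compound 3 `CN(C)c1ccc(C2CC(c3ccccc3)=NN2C2=NC(=O)/C(=C3\C(=O)Nc4ccc(Br)cc43)S2)cc1` gives 450 nM, the lowest number of the three, though compound 1 sits close enough that the pair cannot be ordered: a 1.4-fold lower number from compound 1 to compound 3 (0.15 log units; within the scatter). The step of a 42-fold lower number from compound 2 to compound 3 (1.62 log units; beyond the scatter) is the large one in this set.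

Compound 4 `CN(C)c1ccc(C2CC(c3ccccc3)=NN2C2=NC(=O)/C(=C3\C(=O)Nc4ccc(Cl)cc43)S2)cc1` differs from compound 3 by a single change: chloro in place of bromo on an aromatic carbon. Going by the values given here, no measured step exchanges one halogen for another, so the only direct guidance is the step from compound 2 to compound 3, which shows that a halogen at this place matters greatly compared with hydrogen. Since compound 4 keeps a halogen there, the expected step of a 1.6-fold higher number from compound 3 to compound 4 (0.19 log units; within the scatter) is small, most likely within the scatter, with a slight lean toward a higher number. Compound 4 is therefore estimated at 700 nM, with a range from 250 nM to 2000 nM in this assay.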

Compound 4, concentration for total growth inhibition: 430 nM
Compound 4: middle estimate off by 1.6-fold (0.21 log units), on the high side; measured number inside the range.
By their numbers in this assay, from the lowest: compounds 4, 3 and 1 (each within the scatter of the next); then compound 2.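

In this assay, going by these compounds alone, the step of a 1.0-fold lower number from compound 3 to compound 4 (0.02 log units; within the scatter) gives the first direct exchange of one halogen for another at this aromatic carbon, and it does not separate chloro from bromo. The step of a 44-fold lower number from compound 2 to compound 4 (1.64 log units; beyond the scatter) is large, which shows that the difference from hydrogen seen with bromo in compound 3 is also seen with chloro, so it is not peculiar to bromo. Nothing measured beyond these numbers speaks to why the two halogens give such similar values here.

The compounds shown leave open whether fluoro, methoxy or an amine at this place would stay close to the two halogens or return toward compound 2. On these data alone, it also remains open whether chloro would match bromo with 2-hydroxyphenyl on the saturated ring carbon, as in compound 1.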